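The source may report more compounds than this note shows. Statements on the series, on what has been measured and on what is new or still open speak of the compounds shown alone.

Three ureas that carry a long saturated chain on one nitrogen and an aromatic ring on the other have been measured in an assay on microsomes from intestinal mucosa for inhibition of acyl-CoA:cholesterol acyltransferase (Oryctolagus cuniculus); a higher number here means a weaker inhibitor, a lower number a stronger inhibitor. Compound 1, `CCCCCCCCCCCCCCCCCCNC(=O)Nc1c(C(C)C)cccc1C(C)C`, gives 48 nM in this assay. Compound 2, `CCCCCCCCCCCCCCNC(=O)Nc1ccc(F)cc1F`, gives 340 nM in this assay. Compound 3, `CCCCCCCCCCNC(=O)Nc1c(C)cccc1C(C)C`, gives 210 nM in this assay, the second highest of the three numbers; compound 3 sits within the scatter of compound 2, while compound 1 shows a lower number that lies beyond the scatter. Compound 4, `CCCCCCCCCCNC(=O)Nc1c(C)cccc1C(C)(C)C`, has not yet been measured. Compound 4 differs from compound 3 in a single place: methyl in place of hydrogen on a saturated chain carbon bound to an aromatic carbon and two saturated chain carbons. For the measured compounds named here, no pair of measured compounds is separated by a change of this kind, so the size of this step cannot be read off from any measured pair. The expectation is a small step, either nothing beyond the scatter or a modest move toward a lower number, as a 1.4-fold lower number from compound 3 to compound 4 (0.15 log units; within the scatter). Compound 4 is therefore estimated at 150 nM, with a range from 50 nM to 450 nM.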

Compound 4, half-maximal inhibitory concentration: 200 nM
Estimate against measurement, compound 4: 1.3-fold (0.12 log units) below; the measured number falls inside the stated range.
By their numbers in this assay, from the lowest: compound 1; then compounds 4, 3 and 2 (each within the scatter of the next).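

For the compounds shown here, this is the first step that can be read at this position: isopropyl to tert-butyl, with methyl in place of hydrogen on a saturated chain carbon bound to an aromatic carbon and two saturated chain carbons, gives a 1.1-fold lower number from compound 3 to compound 4 (0.02 log units; within the scatter) in this assay. Going by these compounds alone, the earlier compounds offered no pair separated by a single change, so this is the first direct sign that, with the chain of compound 3 kept in place, this added methyl leaves the number within the scatter. No measurement on hand offers an explanation for this result.

As far as these compounds go, whether a larger group at this place, such as cyclohexyl or phenyl, or a hydroxyl on the same carbon would move the number remains open. From the compounds shown here alone, it is also open whether the same methyl would give a similar step on a compound with a longer chain.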